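Aryl exchange at the shared core: expectation for compound 3

A few compounds are considered here, and "the series" means these few. Any claim that something is new, unique, unknown or untested is made for them only; others in the source may bear on it.

For the measured compounds named here, compound 2 `CCCCCCCCc1ccc(OCC(=O)Cn2nnc(-c3cccnc3)n2)cc1` stands lowest of the two numbers measured so far: in an assay on microsomes from brain for inhibition of Fatty-acid amide hydrolase 1 (Rattus norvegicus), read by fluorescence and HPLC, with a stated time of 60 min (on this read-out lower numbers stand for stronger inhibition and higher numbers for weaker inhibition), compound 2 gives 23 nM. Going by the values given here, its only neighbour is compound 1 `CCCCCCCCc1ccc(OCC(=O)Cn2nnc(-c3ccc(S(=O)(=O)N(C)C)cc3)n2)cc1`, which in this assay gives 590 nM. Among the compounds with values here, the single measured step, a 26-fold lower number from compound 1 to compound 2 (1.41 log units; beyond the scatter), shows that exchanging the aryl group on this aromatic carbon of the shared core moves the read-out a long way.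

Compound 3 `CCCCCCCCc1ccc(OCC(=O)Cn2nnc(-c3cccc(C(=O)O)c3)n2)cc1` is not yet measured. It differs from compound 2 by 3-carboxyphenyl in place of pyridin-3-yl on an aromatic carbon. Within the data shown here, the only step that bears on this change is a 26-fold lower number from compound 1 to compound 2 (1.41 log units; beyond the scatter), which was large and ran from a substituted carbon-only ring to pyridin-3-yl. Compound 3 returns to a substituted carbon-only ring, but with 3-carboxyphenyl rather than 4-(dimethylsulfamoyl)phenyl, and no carboxy group has been measured in this series, so the direction is better supported than the size.

On that basis compound 3 is expected to give about 150 nM, within a range of 30 nM to 700 nM. This estimate means an expected step of a 6.5-fold higher number from compound 2 to compound 3 (0.81 log units; beyond the scatter).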

Compound 3, half-maximal inhibitory concentration: 36 nM
Compound 3: the middle estimate sits 4.2-fold (0.62 log units) above what was measured, and the stated range covers the measured number.
By their numbers in this assay, from the lowest: compounds 2 and 3 (each within the scatter of the next); then compound 1.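

At this aromatic carbon of the shared core, a carbon-only ring is compatible with a low number in this assay: a 1.6-fold higher number from compound 2 to compound 3 (0.19 log units; within the scatter), a step within the scatter, so 3-carboxyphenyl and pyridin-3-yl cannot be told apart here, even though the entering group brings a hydrogen-bond donor and more heavy atoms. The large change seen earlier therefore does not follow the ring nitrogen alone, as a 16-fold lower number from compound 1 to compound 3 (1.21 log units; beyond the scatter), a step beyond the scatter, reproduces most of the gap without any ring nitrogen, leaving compound 1 with its 4-(dimethylsulfamoyl)phenyl apart from the other two compounds. Nothing on hand accounts for this separation or for the match between compound 2 and compound 3.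

The compounds shown leave open whether the carboxylic acid contributes anything of its own, which a plain phenyl ring, a methyl ester or a primary amide at this carbon would help to separate. They also leave open whether this aryl reading holds when the octyl chain is replaced by a shorter chain.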